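Urea chain variation on the shared core: notes

The compounds below may be only part of what the source reports. "The series", "measured", "known", "first", "only" and "open" are said of these compounds alone.

Measured so far in a functional assay on U-87MG ATCC cells for cytotoxicity against U-87 MG (Homo sapiens), read by MTT assay, with a stated time of 72 h; a higher number here means a weaker inhibitor, a lower number a stronger inhibitor:
compound 1, `CCCNC(=O)Nc1nc2ccc(-c3cnc(OC)c(NS(=O)(=O)c4ccc(F)cc4)c3)cn2n1`, 420 nM
compound 2, `COc1ncc(-c2ccc3nc(NC(=O)NCC(=O)N4CCCC4)nn3c2)cc1NS(=O)(=O)c1ccc(F)cc1`, 1000 nM

Compound 1 gives the lowest of the two numbers seen in this assay; its nearest neighbour is compound 2, reached by a 2.4-fold higher number from compound 1 to compound 2 (0.38 log units; beyond the scatter), a step that puts (pyrrolidin-1-yl)carbonyl in place of ethyl on a saturated chain carbon bound to an amide-type nitrogen.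

Compound 3, `COc1ncc(-c2ccc3nc(NC(=O)NCCN4CCN(C)CC4)nn3c2)cc1NS(=O)(=O)c1ccc(F)cc1`, is not yet measured. It differs from compound 1 by 4-methylpiperazin-1-yl in place of methyl on a saturated chain carbon, two bonds along the chain from an amide-type nitrogen. Among the measured compounds shown here, the only measured step that bears on it is the one from compound 1 to compound 2, where a larger group on the chain beyond the urea went together with a modestly higher number. The change to compound 3 is likewise an enlargement at the end of that chain, though with a different group, so a step of about the same size in the same direction, or none beyond the scatter, is expected for compound 3, namely a 1.8-fold higher number from compound 1 to compound 3 (0.25 log units; within the scatter). In this assay compound 3 is therefore estimated at 750 nM, with a range from 300 nM to 1900 nM.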

Compound 3, half-maximal inhibitory concentration: 760 nM
Beside the measured number, compound 3's estimate is 1.0-fold (0.01 log units) below it; low and high end bracket the measured number.
By their numbers in this assay, from the lowest: compounds 1, 3 and 2 (each within the scatter of the next, the first and the last beyond it).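

In this assay, the step to the 4-methylpiperazin-1-yl end gives a 1.8-fold higher number from compound 1 to compound 3 (0.26 log units; within the scatter), so this position on a saturated chain carbon, two bonds along the chain from an amide-type nitrogen, accepts a six-membered non-aromatic ring with no change that can be told from the scatter. Among the compounds shown here, the comparison of the two larger chain ends gives a 1.3-fold lower number from compound 2 to compound 3 (0.12 log units; within the scatter), so the (4-methylpiperazin-1-yl)methyl and (pyrrolidin-1-yl)carbonyl groups cannot be separated here, and a 2.4-fold higher number from compound 1 to compound 2 (0.38 log units; beyond the scatter) remains the only step beyond the scatter, which means that enlargement at this chain end does not go with a clear rise in the number across all three compounds, with compound 3 as the case that does not show one. Nothing available here bears on the reason for these numbers.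

The compounds shown leave open how a morpholine ring or a primary amine at the end of this chain would read, and whether a longer chain between the urea and the 4-methylpiperazin-1-yl group would move the number beyond the scatter. Also open is whether a carboxylic acid at the same chain end would stay among these compounds or fall clearly apart from them.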